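The compounds below may be only part of what the source reports. "The series", "measured", "known", "first", "only" and "open" are said of these compounds alone.

Compound 1 `c1ccc(NCc2cc3ccccc3[nH]2)cc1`: 100000000 nM
Compound 2 `Cn1c(CNc2ccccc2)cc2ccccc21`: 10000000 nM

In an assay on isolated protein for inhibition of Amine oxidase [flavin-containing] A (Homo sapiens) (on this read-out lower numbers stand for stronger inhibition and higher numbers for weaker inhibition), compound 2 gives the lowest of the two numbers, with compound 1 showing a 10-fold lower number from compound 1 to compound 2 (1.00 log units; beyond the scatter). Compound 3 `CN(Cc1cc2ccccc2n1C)c1ccccc1` differs from compound 2 by methyl in place of hydrogen on a nitrogen on an aromatic ring. Among the compounds with values here, the only step seen so far, a 10-fold lower number from compound 1 to compound 2 (1.00 log units; beyond the scatter), also added a methyl to a nitrogen, though a different one, so a step of similar direction and size is expected here. Compound 3 is therefore estimated at 3000000 nM, in the range 500000 nM to 20000000 nM, meaning a 3.3-fold lower number from compound 2 to compound 3 (0.52 log units; beyond the scatter).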

Compound 3, inhibition constant: 6000000 nM
Beside the measured number, compound 3's estimate is 2.0-fold (0.30 log units) below it, within the range that was stated.
By their numbers in this assay, from the lowest: compounds 3 and 2 (each within the scatter of the next); then compound 1.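

In this assay, methyl in place of hydrogen on a nitrogen on an aromatic ring gives a 1.7-fold lower number from compound 2 to compound 3 (0.22 log units; within the scatter), so at this position the methyl cannot be told apart from the hydrogen. The earlier methyl, placed on the other nitrogen, gave a step beyond the scatter: a 10-fold lower number from compound 1 to compound 2 (1.00 log units; beyond the scatter). Nothing available explains this difference between the two nitrogens.

Only methyl has been shown at this nitrogen, so a longer chain such as ethyl or propyl could behave differently. From the compounds shown here alone, a carbonyl attached there, forming an amide, also remains open.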